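Coumarin-free title: Swapping a chlorophenyl for a bromophenyl

The source may hold more compounds than are shown below. What is called first, only, known or untested is meant among the compounds shown, and "the series" means these compounds.

Measured so far:
compound 1, `Cc1ccc(OCC(=O)NNC(=O)c2cc3ccccc3oc2=O)c(C(=O)c2cccc(Cl)c2)c1`, 67300 nM
compound 2, `Cc1ccc(OCC(=O)NNC(=O)c2cc3ccccc3oc2=O)c(C(=O)c2ccc(Cl)cc2)c1`, 57800 nM

Both compounds share one core and differ only in the halogenated ring on the carbonyl carbon. In a functional assay on Ehrlich cells (Mus musculus) for cytotoxicity, read by trypan blue exclusion, with a stated time of 48 h (a lower number here means a stronger inhibitor, a higher number a weaker inhibitor), compound 1 gives 67300 nM and compound 2 gives 57800 nM. For the measured compounds named here, the only step seen so far, a 1.2-fold lower number from compound 1 to compound 2 (0.07 log units; within the scatter), lies within the scatter, so compound 2 stands among two numbers that cannot be told apart.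

Compound 3, `Cc1ccc(OCC(=O)NNC(=O)c2cc3ccccc3oc2=O)c(C(=O)c2cccc(Br)c2)c1`, has not been measured. The change is 3-bromophenyl in place of 4-chlorophenyl on a carbonyl carbon. Going by the values given here, it bears on the one step already seen, since that step also moved a chlorine between the same two places of the ring and changed nothing beyond the scatter. Bromine in place of chlorine is the only new element, and no measured pair speaks to it. No step beyond the scatter is therefore expected; compound 3 is estimated at 65000 nM, within 30000 nM to 140000 nM. That expected step is a 1.1-fold higher number from compound 2 to compound 3 (0.05 log units; within the scatter).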

Compound 3, half-maximal inhibitory concentration: 68500 nM
The estimate for compound 3 lay 1.1-fold (0.02 log units) below the measured number; the range from low to high includes it.
By their numbers in this assay, from the lowest: compounds 2, 1 and 3 (each within the scatter of the next).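

The halogen itself now has a reading: with bromo in place of chloro on an aromatic carbon, this assay shows a step within the scatter (a 1.0-fold higher number from compound 1 to compound 3 (0.01 log units; within the scatter)). A change of both the halogen and its place on the ring, 3-bromophenyl in place of 4-chlorophenyl on a carbonyl carbon, also stays within the scatter (a 1.2-fold higher number from compound 2 to compound 3 (0.07 log units; within the scatter)), so these three halogenated rings cannot be told apart in this assay. No supporting measurement is available to explain this sameness.

Going by these compounds, all three compounds carry a single chlorine or bromine on this ring, so it remains open whether an amine, a carboxylic acid or a methoxy group in that place would give a different number. On these data alone, it also remains open whether 4-bromophenyl would match its 4-chlorophenyl counterpart.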